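Trifluoromethyl Gives Way to Nitro in Compound 3

A few compounds are considered here, and "the series" means these few. Any claim that something is new, unique, unknown or untested is made for them only; others in the source may bear on it.

Among the measured compounds shown here, in a functional assay with Homo sapiens as the target (on this read-out higher numbers stand for weaker inhibition and lower numbers for stronger inhibition), compound 1 `CC(C)[C@H](NC(=O)COc1cccc2ccccc12)C(=O)N[C@@H](CC(=O)O)C(=O)COc1ccccc1` gives 11200 nM and compound 2 `CC(C)[C@H](NC(=O)COc1cccc2ccccc12)C(=O)N[C@@H](CC(=O)O)C(=O)COc1ccc(C(F)(F)F)cc1` gives 12300 nM, so compound 2 stands level with the only other measured compound. Compound 3 `CC(C)[C@H](NC(=O)COc1cccc2ccccc12)C(=O)N[C@@H](CC(=O)O)C(=O)COc1ccc([N+](=O)[O-])cc1` carries nitro in place of trifluoromethyl on an aromatic carbon, para to a large group: nitro in place of trifluoromethyl on an aromatic carbon. For the measured compounds named here, the one measured step that bears on this change, a 1.1-fold higher number from compound 1 to compound 2 (0.04 log units; within the scatter), put trifluoromethyl in place of hydrogen on that carbon and stayed within the scatter. The expected step is therefore also small, a 1.1-fold lower number from compound 2 to compound 3 (0.05 log units; within the scatter), and none beyond the scatter is anticipated in this assay. The estimate for compound 3 is 11000 nM, with an expected range of 5000 nM to 24000 nM.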

Compound 3, half-maximal inhibitory concentration: 22800 nM
Estimate against measurement, compound 3: 2.1-fold (0.32 log units) below; the measured number falls inside the stated range.
By their numbers in this assay, from the lowest: compounds 1, 2 and 3 (each within the scatter of the next, the first and the last beyond it).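

In this assay, nitro in place of hydrogen on this aromatic carbon gives a 2.0-fold higher number from compound 1 to compound 3 (0.31 log units; beyond the scatter), a modest change and the first at this place to pass beyond the scatter. Nitro in place of trifluoromethyl gives a 1.9-fold higher number from compound 2 to compound 3 (0.27 log units; within the scatter), so the two groups cannot be told apart here, even though only nitro separates from hydrogen. No evidence is available to account for this result. On these data alone, whether an amine or a carboxylic acid on this carbon would shift the number further, and in which direction, remains open.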